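The compounds below may be only part of what the source reports. "The series", "measured", "known", "first", "only" and "open" are said of these compounds alone.

Compound 1 `c1cncc(-c2nnc(-c3c[nH]c4ccccc34)o2)c1` gives 5400 nM in a functional assay on MCF7 cells (Homo sapiens) for cytotoxicity, read by MTT assay; on this read-out higher numbers stand for weaker inhibition and lower numbers for stronger inhibition. Compound 2 `COc1ccc(-c2nnc(-c3c[nH]c4ccccc34)o2)cc1` reaches only the limit of > 1000000 nM in this assay. Compound 3 `COc1ccc(-c2nnc(-c3c[nH]c4ccccc34)o2)cc1OC` gives 557000 nM in this assay.

Compound 3 stands highest of the two numbers in this assay, with compound 1 far below it. Compound 4 `COc1ccc(-c2nnc(-c3c[nH]c4ccccc34)o2)c(OC)c1OC` differs from compound 3 by methoxy in place of hydrogen on an aromatic carbon. Going by the values given here, one measured step bears on this change: an at least 1.7-fold lower number from compound 2 to compound 3 (0.25 log units; that floor lies within the scatter), also a methoxy in place of hydrogen on an aromatic carbon, which starts from a limit and so gives only a floor that lies within the scatter. A further methoxy is therefore expected to move the number little, if at all, and the expected step is a 1.6-fold lower number from compound 3 to compound 4 (0.20 log units; within the scatter). Compound 4 is estimated at 350000 nM, within 60000 nM to 1500000 nM in this assay.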

Compound 4, half-maximal inhibitory concentration: 121000 nM
Estimate against measurement, compound 4: 2.9-fold (0.46 log units) above, within the range that was stated.
By their numbers in this assay, from the lowest: compound 1; then compound 4; then compound 3. At a limit, above all of these: compound 2.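

In this assay, going by these compounds alone, methoxy in place of hydrogen on this aromatic carbon, ortho to a large group and ortho to a methoxy group, gives a 4.6-fold lower number from compound 3 to compound 4 (0.66 log units; beyond the scatter), the first step of this change that can be read as a full number. Compound 2 sits at a limit, so the earlier methoxy step gave only a floor: the limit of > 1000000 nM in this assay, at which 1 of the 4 values shown sits. On these data alone, whether a hydroxy group or an amine on this carbon would give a comparable step stays open, as does whether methoxy here would give the same step without the other two methoxy groups.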